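This account rests on a few compounds, and the source may have more. Where it says the series, first, only, none or still open, it means among the compounds named here.

Compound 1 `CCCCCCCCCCCCCCCCCCNC(=O)[C@H]1CSC(Cc2ccccc2)N1` in a functional assay on RH7777 cells (Homo sapiens) for antiproliferative activity against RH7777 (Rattus norvegicus), read by sulforhodamine B assay (on this read-out lower numbers stand for stronger inhibition and higher numbers for weaker inhibition), gives > 20000 nM, which is a limit of the assay rather than a measured number.
Compound 2 `CCCCCCCCCCCCCCCCCCNC(=O)[C@H]1CSC(c2ccc(Br)cc2)N1` gives > 20000 nM, again only a limit.
Compound 3 `CCCCCCCCCCCCCCCCCCNC(=O)[C@H]1CSC(c2ccc(C#N)cc2)N1` gives > 20000 nM, also only a limit.

Compound 1 therefore stands at the edge of what this assay can report, and the two other compounds stand at the same edge, so none of the three can be placed above or below another. Compound 4 `CCCCCCCCCCCCCCCCCCNC(=O)[C@H]1CSC(c2c(Cl)cccc2Cl)N1` has not yet been measured; it differs from compound 1 in one place: 2,6-dichlorophenyl in place of benzyl on a saturated ring carbon. The measured steps that bear on this change are the two in which another aryl group replaces benzyl on the same ring carbon, a step that the two limits leave unreadable from compound 1 to compound 2 and a step that the two limits leave unreadable from compound 1 to compound 3, together with the swap between them, a step that the two limits leave unreadable from compound 2 to compound 3. None of these three steps has a readable size, because every value sits at the limit of > 20000 nM in this assay, at which 3 of the 3 values shown sit. The data thus give no sign that any aryl group on that ring carbon brings the activity into the measurable range. For compound 4 the expected step is a number no higher from compound 1 to compound 4 (the limit leaves the size open), that is, no movement beyond the scatter is expected. Compound 4 is therefore estimated at 20000 nM, within a range from 6000 nM to 60000 nM, with a good chance that this assay again reports only a limit.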

Compound 4, half-maximal inhibitory concentration: > 20000 nM
Compound 4 ended at the assay's limit (the forecaster's own chance of this, stated with the estimate: 70%); the middle value sits exactly at the limit.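

Compound 4 also gives only a limit in this assay, so its steps from compound 1, compound 2 and compound 3 cannot be read, and none of these compounds can be ranked against another: the limit of > 20000 nM in this assay, at which 4 of the 4 values shown sit. The compounds shown leave open how far each true value lies beyond that limit and whether any aryl group on that ring carbon can give a measurable value.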